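The source may hold more compounds than are shown below. What is called first, only, known or untested is meant among the compounds shown, and "the series" means these compounds.

Of the compounds shown here, three have been measured in a functional assay on cells (Lymphocyte, Homo sapiens); on this read-out lower numbers stand for stronger inhibition and higher numbers for weaker inhibition. Compound 1 `Cc1cccc(NC(=O)N2CCN(c3nc(N)nc4sc(-c5ccc(F)cc5)nc34)CC2)c1` gives 300 nM, compound 2 `Nc1nc(N2CCN(C(=O)COc3ccc(Cl)cc3)CC2)c2nc(CCOc3ccc(F)cc3)sc2n1` gives 3540 nM, and compound 3 `COc1ccc(OCC(=O)N2CCN(c3nc(N)nc4sc(-c5ccc(F)cc5)nc34)CC2)cc1` gives 40 nM. Among these, compound 2 stands at the weak end: its number is the highest of the three, with compound 1 nearest and compound 3 furthest away.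

Compound 4 `Cc1ccc(-c2nc3c(N4CCN(C(=O)COc5ccc(Cl)cc5)CC4)nc(N)nc3s2)cc1` has not yet been measured. It differs from compound 2 in one place: 4-methylphenyl in place of 2-(4-fluorophenoxy)ethyl on an aromatic carbon. Going by the values given here, the only measured single-point step, a 7.5-fold lower number from compound 1 to compound 3 (0.88 log units; beyond the scatter), concerns a different part of the molecule, the group on the carbonyl carbon, so it does not speak directly to this change. What the values do show is that compound 1 and compound 3, which each carry an aromatic ring directly on that five-membered ring carbon, sit far below compound 2, which carries the longer 2-(4-fluorophenoxy)ethyl there. Compound 4 shares that directly attached ring arrangement while keeping the side chain of compound 2, so a clear fall in this assay is expected, a 51-fold lower number from compound 2 to compound 4 (1.70 log units; beyond the scatter). Compound 4 is therefore estimated at 70 nM, within a range of 15 nM to 350 nM.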

Compound 4, half-maximal inhibitory concentration: 350 nM
Compound 4: middle estimate off by 5.0-fold (0.70 log units), on the low side; low and high end bracket the measured number.
By their numbers in this assay, from the lowest: compound 3; then compounds 1 and 4 (each within the scatter of the next); then compound 2.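

In this assay, replacing 2-(4-fluorophenoxy)ethyl with 4-methylphenyl on the aromatic carbon of the five-membered ring gives a 10-fold lower number from compound 2 to compound 4 (1.00 log units; beyond the scatter) while the rest of the molecule stays the same. Going by these compounds alone, the earlier step concerned only the group on the carbonyl carbon, so this is the first evidence that a change at this ring position alone can move the number beyond the scatter. No measurement shown explains why this change lowers the number.

The swap removes the chain's oxygen and fluorine and adds a methyl in a single step, so the contribution of each part remains unresolved. Also open, from the compounds shown here alone, is how a plain phenyl, a benzyl or a 2-phenylethyl group on this carbon would compare, with the same group on the carbonyl carbon.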